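Tetrahalophthalimides with azaaryl nitrogen substituents: inhibition read-out

The compounds below may be only part of what the source reports. "The series", "measured", "known", "first", "only" and "open" are said of these compounds alone.

Measured so far:
compound 1, `O=C1c2c(Br)c(Br)c(Br)c(Br)c2C(=O)N1Cc1ccccn1`: 54%
compound 2, `O=C1c2cc(Cl)c(Cl)cc2C(=O)N1c1ccccn1`: 17%

In a functional assay on the whole organism (serum, strain Swiss albino) with Rattus norvegicus as the target, read by spectrophotometry, with a stated time of 14 days, at a dose of 10 mg/kg by the oral route (on this read-out higher numbers stand for more inhibition at the one dose given (going by the name of the read-out) and lower numbers for less inhibition), compound 1 gives 54%, the higher of the two numbers recorded. Compound 2 gives 17% in this assay, a value lying beyond the usual scatter below that of compound 1. Within the data shown here, compound 1 and compound 2 differ in more than one place, so their two values show only that the pair is separated, not what any single change does.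

Compound 3, `O=C1c2c(Br)c(Br)c(Br)c(Br)c2C(=O)N1c1ncccn1`, is not yet measured in this assay. Its difference from compound 1 is:
pyrimidin-2-yl in place of (pyridin-2-yl)methyl on an amide-type nitrogen in a ring
Both compounds keep the same tetrabrominated core; only the substituent on the amide-type nitrogen changes.

Among the measured compounds shown here, no single-change step exists between measured compounds, so the size of the step cannot be read from the data. Given that compound 2, carrying a directly attached six-membered aromatic ring, gives 17%, a moderate decrease from compound 1 to compound 3 is expected, about a number 14 percentage points lower from compound 1 to compound 3 (beyond the scatter), though it may fall within the scatter. For compound 3 the estimated read-out in this assay is 40%, within the range 20% to 60%.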

Compound 3, a percentage reported as inhibition, in the whole organism at one dose (the size of the read-out at that dose, not a potency): 19%
The estimate for compound 3 lay 21 percentage points above the measured number; the whole stated range lies above it.
By their numbers in this assay, from the lowest: compounds 2 and 3 (each within the scatter of the next); then compound 1.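

In this assay, among these compounds, pyrimidin-2-yl in place of (pyridin-2-yl)methyl on the amide-type nitrogen in a ring gives the first single-change step: a number 35 percentage points lower from compound 1 to compound 3 (beyond the scatter). With the tetrabrominated core held constant, this shows that the read-out depends strongly on the substituent at this position, which the separation between compound 1 and compound 2 could not show, as that pair differs in more than one place. The step bundles two structural differences, a group of 7 heavy atoms with one six-membered aromatic ring with 1 hetero atom giving way to a group of 6 heavy atoms with one six-membered aromatic ring with 2 hetero atoms, and no measurement here accounts for its size.

The compounds shown leave open whether the step follows from the loss of the carbon link to the ring or from the change in the ring itself, a question that (pyrimidin-2-yl)methyl on the same core would address directly. Also open, from the compounds shown here alone, is how the read-out responds at this position to a longer chain ending in the pyridin-2-yl ring, or to a simple amine in place of the aromatic ring.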